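The source may report more compounds than this note shows. Statements on the series, on what has been measured and on what is new or still open speak of the compounds shown alone.

Measured so far:
- compound 1, `COc1c(C(=O)NCC(C)(C)CC2=C(O)C(=O)c3ccccc3C2=O)ccc2ccccc12`: 66900 nM
- compound 2, `COc1cc(C(=O)NCC(C)(C)CC2=C(O)C(=O)c3ccccc3C2=O)c(O)c2ccccc12`: 8620 nM

Both numbers come from a functional assay on KB cells (Homo sapiens) for cytotoxicity, read by resazurin assay, with a stated time of 3 days; a lower number here means a stronger inhibitor, a higher number a weaker inhibitor. Among the compounds with values here, compound 2 gives the lowest of the two numbers, and its only neighbour, compound 1, sits well above it, a gap beyond the usual scatter of this assay. Compound 2 is therefore the stronger of the two measured compounds.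

Compound 3, `COc1cc(C(=O)NCC(C)(C)CC2=C(O)C(=O)c3ccccc3C2=O)c(OC)c2ccccc12`, is the next compound to be measured. It differs from compound 2 in a single spot: methyl in place of hydrogen on an oxygen on an aromatic ring. Read one bond further out, the change is hydroxy to methoxy, so the free hydroxyl of compound 2 is capped. Within the data shown here, no single-point step between measured compounds is available to calibrate this change. What the data do show is that compound 1, which carries a methoxy and no hydroxy on its aromatic ring, is the weaker of the two measured compounds. On that basis the step from compound 2 to compound 3 is expected to run toward higher numbers, a 3.5-fold higher number from compound 2 to compound 3 (0.54 log units; beyond the scatter), rather than to stay within the scatter. Compound 3 is thus expected to give about 30000 nM in this assay, with a likely range from 8000 nM to 90000 nM.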

Compound 3, half-maximal inhibitory concentration: 47000 nM
Compound 3: the middle estimate sits 1.6-fold (0.19 log units) below what was measured, and the stated range covers the measured number.
By their numbers in this assay, from the lowest: compound 2; then compounds 3 and 1 (each within the scatter of the next).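

In this assay, capping the hydroxy as a methoxy gives a 5.5-fold higher number from compound 2 to compound 3 (0.74 log units; beyond the scatter), so at this spot on the aromatic ring the hydrogen on the oxygen makes a real difference to the number, and a methyl there does not preserve the result of compound 2. The other new step, methoxy in place of hydrogen on an aromatic carbon, gives a 1.4-fold lower number from compound 1 to compound 3 (0.15 log units; within the scatter), which lies within the scatter, so this added methoxy leaves compound 1 and compound 3 indistinguishable in this measurement. Nothing in the available data explains why the free hydroxy and the methoxy part ways here.

The compounds shown leave open whether the number depends on the hydrogen itself or on the size of what replaces it, which an ethoxy on the same oxygen, or an amine in place of the hydroxy, could begin to separate. They also leave open whether the hydroxy would keep its lower number with a different chain joining the amide to the rest of the shared core.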